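Solubility notes on an aryloxy-quinoline amine series

A few compounds are considered here, and "the series" means these few. Any claim that something is new, unique, unknown or untested is made for them only; others in the source may bear on it.

The series shares one core carrying a diaryl ether on one side and a diamine-linked benzyl group on the other. Compound 1 `COc1ccc(Oc2ccc3c(NCCCNCc4cc(F)ccc4OC)ccnc3c2)cc1` gives, in a physicochemical assay for solubility, with a stated time of 18 h, at pH 7.4 (a lower number here means a less soluble compound, a higher number a more soluble compound), a value of 14500 nM. Compound 2 `COc1ccc(F)cc1CNCCCNc1ccnc2cc(Oc3cccc(N(C)C)c3)ccc12` gives in this assay 14500 nM. Compound 3 `COc1ccc(Oc2ccc3c(NCCCNCc4cccc(OC)c4O)ccnc3c2)cc1` gives in this assay 14500 nM. Compound 4 `COc1cccc(CNCCCNc2ccnc3cc(Oc4cccc(N(C)C)c4)ccc23)c1O` has not yet been measured in this assay.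

Compound 2 differs from compound 1 by 3-(dimethylamino)phenyl in place of 4-methoxyphenyl on an oxygen on an aromatic ring. That change produced no change at the digits printed from compound 1 to compound 2 (within the scatter). Compound 3 differs from compound 1 by 2-hydroxy-3-methoxyphenyl in place of 5-fluoro-2-methoxyphenyl on a saturated chain carbon bound to an amine nitrogen, a change that produced no change at the digits printed from compound 1 to compound 3 (within the scatter). Compound 3 therefore stands level with compounds 1 and 2 in this assay at the digits given.

Compound 4 differs from compound 3 by 3-(dimethylamino)phenyl in place of 4-methoxyphenyl on an oxygen on an aromatic ring. The place of this change is worded identically to the place of the change from compound 1 to compound 2, so it is the same change, made a second time on a core that differs by 2-hydroxy-3-methoxyphenyl in place of 5-fluoro-2-methoxyphenyl on a saturated chain carbon bound to an amine nitrogen. For the measured compounds named here, since this change gave no change at the digits printed from compound 1 to compound 2 (within the scatter) in the one pair where it has been measured, and since the two cores gave no change at the digits printed from compound 1 to compound 3 (within the scatter) between them, compound 4 is expected to show a step of no change at the digits printed from compound 3 to compound 4 (within the scatter) in this assay. The estimate for compound 4 in this assay is 14500 nM, with an expected range from 7000 nM to 29000 nM. This expectation rests on three compounds only, and compound 4 will show whether the level holds.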

Compound 4, solubility: 14500 nM
Beside the measured number, compound 4's estimate shows no gap at the digits printed; the range from low to high includes it.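

In this assay, 3-(dimethylamino)phenyl in place of 4-methoxyphenyl on an oxygen on an aromatic ring produced no change at the digits printed from compound 3 to compound 4 (within the scatter), which reads as the earlier pair did, with no change at the digits printed from compound 1 to compound 2 (within the scatter), and the second change, 2-hydroxy-3-methoxyphenyl in place of 5-fluoro-2-methoxyphenyl, likewise produced no change at the digits printed from compound 2 to compound 4 (within the scatter). For the compounds shown here, the four compounds therefore form a closed square in which each change carries from one core to the other with no step beyond the scatter, but this covers only these two cores and, with no step of measurable size in the set, does not show that a step of real size would carry over in the same way. No measured evidence is available to account for the level values.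

The compounds shown vary only the aryl group on the ether oxygen and the aryl group of the benzyl amine, so they leave open how far the level in this assay extends across the series. Whether a carboxylic acid on the aryl ether ring or a longer chain in the diamine link would give a step beyond the scatter remains an open question.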